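Compound 3 to compound 4: a side-chain swap

The compounds below may be only part of what the source reports. "The series", "measured", "known", "first", "only" and "open" are said of these compounds alone.

In a functional assay on KG-1 cells (Homo sapiens) for antiproliferative activity, read by CCK-8 assay, with a stated time of 72 h (a lower number here means a stronger inhibitor, a higher number a weaker inhibitor), compound 1 `Cc1ccc(C(=O)Nc2cccc(C(F)(F)F)c2)cc1-c1ccc2c(-c3cn[nH]c3)n[nH]c2c1` gives > 1000 nM, which is a limit of the assay and not a number. Compound 2 `CCn1cc(-c2n[nH]c3cc(-c4cc(C(=O)Nc5cccc(C(F)(F)F)c5)ccc4C)ccc23)cn1` gives 257 nM. Compound 3 `Cc1ccc(C(=O)Nc2cccc(C(F)(F)F)c2)cc1-c1ccc2c(-c3cnn(CC(C)O)c3)n[nH]c2c1` gives 339 nM, within the scatter of the value for compound 2.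

Substitution on the aromatic nitrogen gave an at least 3.8-fold lower number from compound 1 to compound 2 (0.59 log units; beyond the scatter) and an at least 2.9-fold lower number from compound 1 to compound 3 (0.46 log units; beyond the scatter), both beyond the scatter. For the measured compounds named here, the one measured exchange on the saturated chain carbon bound to that nitrogen gave a 1.3-fold higher number from compound 2 to compound 3 (0.12 log units; within the scatter), within the scatter.

Compound 4 `Cc1ccc(C(=O)Nc2cccc(C(F)(F)F)c2)cc1-c1ccc2c(-c3cnn(CC(=O)N(C)C)c3)n[nH]c2c1` carries dimethylcarbamoyl in place of 1-hydroxyethyl on a saturated chain carbon bound to an aromatic nitrogen. Going by the values given here, no measured compound carries this group, so the precedent is thin.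

Among the compounds with values here, compound 2 and compound 3 are the only precedent at this place, and their step of a 1.3-fold higher number from compound 2 to compound 3 (0.12 log units; within the scatter) supports expecting no change beyond the scatter in this assay. The expected step is a 1.1-fold lower number from compound 3 to compound 4 (0.05 log units; within the scatter). Compound 4 is estimated at 300 nM, with an expected range of 110 nM to 850 nM.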

Compound 4, half-maximal inhibitory concentration: 441 nM
The estimate for compound 4 lay 1.5-fold (0.17 log units) below the measured number; the range from low to high includes it.
By their numbers in this assay, from the lowest: compounds 2, 3 and 4 (each within the scatter of the next). At a limit, above all of these: compound 1.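

In this assay, the saturated chain on the aromatic nitrogen accepts an amide, and the hydrogen-bond donor of 2-hydroxypropyl is not required: with (dimethylcarbamoyl)methyl in its place there is no change beyond the scatter (a 1.3-fold higher number from compound 3 to compound 4 (0.11 log units; within the scatter)), and the same holds against the ethyl of compound 2 (a 1.7-fold higher number from compound 2 to compound 4 (0.23 log units; within the scatter)). A third substituent on that nitrogen also stays clear of the unsubstituted compound (an at least 2.2-fold lower number from compound 1 to compound 4 (0.35 log units; beyond the scatter)), so compounds 2, 3 and 4 all agree on this point. From the compounds shown here alone, for compound 1 the value is a limit and not a number, so the true size of that step stays unknown: the limit of > 1000 nM in this assay, at which 1 of the 4 values shown sits.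

Going by these compounds, whether a carboxylic acid, a dimethylaminoethyl chain or a longer alkyl chain on the aromatic nitrogen would move the number beyond the scatter remains open. So does whether any chain here can go clearly below compound 2.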